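The source may report more compounds than this note shows. Statements on the series, on what has been measured and on what is new or still open speak of the compounds shown alone.

Compound 2 (`CC1(C)[C@H]2CC[C@]1(C)N(Cc1cn(-c3ccc(Br)cc3)nn1)C(=O)C2`) stands at 140 nM in a functional assay on OVCAR-3 cells (Homo sapiens) for inhibition, read by MTT assay, with a stated time of 24 h (on this read-out higher numbers stand for weaker inhibition and lower numbers for stronger inhibition), and compound 1 (`CC1(C)[C@H]2CC[C@]1(C)N(Cc1cn(-c3ccccc3C#N)nn1)C(=O)C2`) at 110 nM so the two are not separated. Compound 3 (`Cc1ccccc1-n1cc(CN2C(=O)C[C@@H]3CC[C@@]2(C)C3(C)C)nn1`) differs from compound 2 by 2-methylphenyl in place of 4-bromophenyl on an aromatic nitrogen. Going by the values given here, only one measured step bears on this place: 4-bromophenyl in place of 2-cyanophenyl gave (a 1.3-fold higher number from compound 1 to compound 2 (0.10 log units; within the scatter)) and so no step beyond the scatter is expected in this assay for the new group. The expected step is a 1.1-fold lower number from compound 2 to compound 3 (0.03 log units; within the scatter) and so lies within the scatter. For compound 3 the estimated value is 130 nM (expected range 50 nM to 330 nM).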

Compound 3, half-maximal inhibitory concentration: 150 nM
Beside the measured number, compound 3's estimate is 1.2-fold (0.06 log units) below it; the measured number falls inside the stated range.
By their numbers in this assay, from the lowest: compounds 1, 2 and 3 (each within the scatter of the next).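

In this assay, 2-methylphenyl on the aromatic nitrogen is not separated from 4-bromophenyl (a 1.1-fold higher number from compound 2 to compound 3 (0.03 log units; within the scatter)). Methyl in place of cyano on an aromatic carbon, a change the earlier pair did not cover, also stays within the scatter (a 1.4-fold higher number from compound 1 to compound 3 (0.13 log units; within the scatter)). No evidence is available to explain these results.

The compounds shown carry only substituted phenyl groups at this position, all within the scatter of one another. They leave open whether an amine or a carboxylic acid on the phenyl, or a longer alkyl chain in its place, would give a step beyond the scatter.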